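The source may report more compounds than this note shows. Statements on the series, on what has been measured and on what is new or still open speak of the compounds shown alone.

Of the compounds shown here, three have been tested so far in a functional assay on the whole organism (strain Holtzman) with Rattus norvegicus as the target; on this read-out higher numbers stand for an effect only at larger amounts of compound and lower numbers for an effect already at smaller amounts. Compound 1 `Cc1nn(C)c2c1C(c1ccccc1Cl)=NCC(=O)N2` gives 2.5 mg/kg. Compound 2 `CCn1nc(C)c2c1NC(=O)CN=C2c1ccccc1Cl` gives 5 mg/kg, and compound 3 `Cc1nn(C(C)C)c2c1C(c1ccccc1Cl)=NCC(=O)N2` gives 20 mg/kg, the highest number of the three; its nearest neighbour is compound 2, and the step of a 4.0-fold higher number from compound 2 to compound 3 (0.60 log units; beyond the scatter) lies beyond the scatter, as does the step of an 8.0-fold higher number from compound 1 to compound 3 (0.90 log units; beyond the scatter). The step of a 2.0-fold higher number from compound 1 to compound 2 (0.30 log units; within the scatter) remains within the scatter.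

Compound 4 `Cc1nn(C2CCCCC2)c2c1C(c1ccccc1Cl)=NCC(=O)N2` differs from compound 3 by cyclohexyl in place of isopropyl on an aromatic nitrogen. The step that bears most directly on this change is the earlier enlargement on the same aromatic nitrogen, an 8.0-fold higher number from compound 1 to compound 3 (0.90 log units; beyond the scatter), which raised the minimum effective dose by a modest amount when isopropyl replaced methyl. A further enlargement to cyclohexyl is therefore expected to move this assay in the same direction, by a step of about a 2.0-fold higher number from compound 3 to compound 4 (0.30 log units; within the scatter), although only the two earlier compounds support this reading. Compound 4 is thus estimated at 40 mg/kg, within a range from 15 mg/kg to 120 mg/kg.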

Compound 4, minimum effective dose: > 40 mg/kg
Compound 4: no number, only a limit (the forecaster's own chance of this, stated with the estimate: 20%); the middle value sits exactly at the limit.
By their numbers in this assay, from the lowest: compounds 1 and 2 (each within the scatter of the next); then compound 3. At a limit, above all of these: compound 4.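

For compound 4 the reading in this assay is a limit and not a number: the limit of > 40 mg/kg in this assay, at which 1 of the 4 values shown sits. The position thus tolerates no gain from the cyclohexyl ring, and enlarging the group on this aromatic nitrogen beyond isopropyl brings no return toward smaller doses. Two steps lie clearly beyond the scatter, an at least 8.0-fold higher number from compound 2 to compound 4 (0.90 log units; beyond the scatter) and an at least 16-fold higher number from compound 1 to compound 4 (1.20 log units; beyond the scatter), so the methyl and ethyl compounds stand well apart from the cyclohexyl one, whereas the floor of an at least 2.0-fold higher number from compound 3 to compound 4 (0.30 log units; that floor lies within the scatter) does not by itself separate cyclohexyl from isopropyl.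

As far as these compounds go, how far compound 4 lies past its limit remains unknown, so the true size of these steps stays open. Also open, from the compounds shown here alone, is whether a phenyl ring, an amine or a carboxylic acid on this nitrogen would follow the same course.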